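Swapping Fluoro for Methoxy on a Shared Core

The source may hold more compounds than are shown below. What is called first, only, known or untested is meant among the compounds shown, and "the series" means these compounds.

Of the compounds shown here, three that share one core have been tested in a functional assay on A549 cells (Homo sapiens) for cytotoxicity, read by sulforhodamine B assay; a higher number here means a weaker inhibitor, a lower number a stronger inhibitor. Compound 1 `C=C1[C@@H](OC(C)=O)C[C@@H]2[C@](C)(COC=O)[C@H](OC(C)=O)CC[C@@]2(C)[C@@H]1C[C@@H](Nc1ccc(O)cc1)C1=CCOC1=O` gives 29100 nM in this assay. Compound 3 `C=C1[C@@H](OC(C)=O)C[C@@H]2[C@](C)(COC=O)[C@H](OC(C)=O)CC[C@@]2(C)[C@@H]1C[C@@H](Nc1cccc(F)c1)C1=CCOC1=O` gives 23200 nM, and the step between them, a 1.3-fold lower number from compound 1 to compound 3 (0.10 log units; within the scatter), lies within the scatter, so that change on the amine nitrogen made no difference that the assay can resolve. Compound 2 `C=C1[C@@H](OC(C)=O)C[C@@H]2[C@](C)(CO[Si](C)(C)C(C)(C)C)[C@H](OC(C)=O)CC[C@@]2(C)[C@@H]1C[C@@H](Nc1cccc(F)c1)C1=CCOC1=O` gives 4060 nM and stands lowest of the three numbers, which here means it is the strongest inhibitor of the set; its step to compound 3 is a 5.7-fold higher number from compound 2 to compound 3 (0.76 log units; beyond the scatter), beyond the scatter, and that step concerns the oxygen on a saturated carbon rather than the group on the amine nitrogen.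

Compound 4 `C=C1[C@@H](OC(C)=O)C[C@@H]2[C@](C)(CO[Si](C)(C)C(C)(C)C)[C@H](OC(C)=O)CC[C@@]2(C)[C@@H]1C[C@@H](Nc1cccc(OC)c1)C1=CCOC1=O` has not yet been measured. It differs from compound 2 in one place: methoxy in place of fluoro on an aromatic carbon. Among the compounds with values here, the only measured step that touches the same aromatic ring is the one from compound 1 to compound 3, and it stayed within the scatter; there is no measured pair in which methoxy replaces fluoro. On that basis the step of a 1.1-fold higher number from compound 2 to compound 4 (0.04 log units; within the scatter) is expected to remain within the scatter, with no clear direction. Compound 4 is therefore estimated to give 4500 nM in this assay, within a range from 1800 nM to 11000 nM.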

Compound 4, half-maximal inhibitory concentration: 17200 nM
Beside the measured number, compound 4's estimate is 3.8-fold (0.58 log units) below it; measured number outside the range, above it.
By their numbers in this assay, from the lowest: compound 2; then compounds 4, 3 and 1 (each within the scatter of the next).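

In this assay, the aromatic ring is not a silent part of the molecule: with the rest of compound 2 held fixed, methoxy in place of fluoro gives a 4.2-fold higher number from compound 2 to compound 4 (0.63 log units; beyond the scatter), a weaker inhibitor by a margin the assay can resolve. The earlier ring step, a 1.3-fold lower number from compound 1 to compound 3 (0.10 log units; within the scatter), stayed within the scatter, but it changed the group and where it sat, whereas here only the group on the same aromatic carbon changes, from fluoro to methoxy. No measurement here explains why so small a swap shifts the number.

The compounds shown do not tell whether the same swap would have a similar effect on the core of compound 3, which carries the smaller group on the oxygen, since this step has been read only with the silyl group in place. Nor do they show whether the weakening is particular to methoxy, as a chloro, methyl or ethoxy group on the same aromatic carbon would be needed to trace how the number follows the group there.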